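This account rests on a few compounds, and the source may have more. Where it says the series, first, only, none or still open, it means among the compounds named here.

Measured so far:
compound 1 `O=C(/C=C(O)/C=C/c1cccc(O)c1)c1cc(Cl)ccc1O`: 62.4%
compound 2 `O=C1/C(=C/c2ccccc2)CCC/C1=C\c1cccc(Br)c1`: 27.2%
compound 3 `COc1cc(/C=C2\CCC/C(=C\c3ccccc3)C2=O)cc(OC)c1OC`: 16.3%

Of the compounds shown here, three have been tested in an assay on isolated protein for inhibition of Alpha glucosidase (Homo sapiens), with stated times of 5 min and 15 min, tested at 50 uM; a higher number here means more inhibition at the concentration tested (going by the name of the read-out), a lower number less inhibition. Compound 2 stands second highest of the three numbers: its nearest neighbour is compound 3, whose value in this assay, 16.3%, lies below it by more than the scatter, while compound 1, with 62.4% in this assay, is the furthest away, well above it and also beyond the scatter.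

The next compound, compound 4 `O=C1/C(=C/c2ccccc2)CCC/C1=C\c1ccc(Cl)cc1`, has not yet been measured in this assay. It differs from compound 2 in one place: 4-chlorophenyl in place of 3-bromophenyl on a double-bonded chain carbon bound to a double-bonded ring carbon. For the measured compounds named here, no measured pair in this set shows what such a change does, so the account rests on compound 2 alone. Because compound 2 gives 27.2% and the change keeps the same count of heavy atoms with only the halogen and its position altered, the expected step from compound 2 to compound 4 is a number 2.2 percentage points lower from compound 2 to compound 4 (within the scatter), no larger than the usual scatter and in no firm direction. Compound 4 is therefore estimated at 25%, with a range from 10% to 42%.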

Compound 4, a percentage reported as inhibition, at one concentration (the size of the read-out at that concentration, not a potency): 27.6%
Estimate against measurement, compound 4: 2.6 percentage points below; low and high end bracket the measured number.
By their numbers in this assay, from the lowest: compound 3; then compounds 2 and 4 (each within the scatter of the next); then compound 1.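

In this assay, for the compounds shown here, 4-chlorophenyl in place of 3-bromophenyl on a double-bonded chain carbon bound to a double-bonded ring carbon gives a number 0.4 percentage points higher from compound 2 to compound 4 (within the scatter) and is the only step in this set that can be read. It shows that at this position one halogen-bearing phenyl can replace the other with the numbers staying within the scatter, although the halogen and its place on the ring differ together, so this single pair cannot separate the two. No measured evidence bears on why the numbers lie so close.

As far as these compounds go, whether an amine or a carboxylic acid on this phenyl ring would stay within the scatter of compound 2 remains open. So does the outcome of a longer chain between this ring and the shared core.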